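This account rests on a few compounds, and the source may have more. Where it says the series, first, only, none or still open, it means among the compounds named here.

Compound 2 (`COCC(C)n1cc(C(=O)C(=O)Nc2ccc(OC)nc2)c2ccccc21`) stands level with compound 1 (`COc1ccc(NC(=O)C(=O)c2cn(C(C)C)c3ccccc23)cn1`) in a physicochemical assay for solubility, in phosphate buffer, at pH 7.4; on this read-out higher numbers stand for higher solubility and lower numbers for lower solubility: compound 2 gives 40000 nM and compound 1 gives 20000 nM on this read-out. Compound 3 (`COc1ccc(NC(=O)C(=O)c2cn(CC3CCCO3)c3ccccc23)cn1`) has (oxolan-2-yl)methyl in place of 1-(methoxymethyl)ethyl on an aromatic nitrogen. Going by the values given here, the only measured step bearing on this, a 2.0-fold higher number from compound 1 to compound 2 (0.30 log units; within the scatter), also altered the group on that nitrogen, but no measured step introduces a ring there. The expected step is a 1.3-fold lower number from compound 2 to compound 3 (0.12 log units; within the scatter) and nothing beyond the scatter is anticipated in this assay for either direction. The estimate for compound 3 is 30000 nM (expected range 12000 nM to 70000 nM).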

Compound 3, solubility: 10000 nM
Compound 3: the middle estimate sits 3.0-fold (0.48 log units) above what was measured; the measured number lies below the stated range.
By their numbers in this assay, from the lowest: compounds 3, 1 and 2 (each within the scatter of the next, the first and the last beyond it).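

In this assay, going by these compounds alone, the exchange of 1-(methoxymethyl)ethyl for (oxolan-2-yl)methyl on the aromatic nitrogen gives a 4.0-fold lower number from compound 2 to compound 3 (0.60 log units; beyond the scatter) and is the first step at this position beyond the scatter. Set against isopropyl, the same (oxolan-2-yl)methyl gives a 2.0-fold lower number from compound 1 to compound 3 (0.30 log units; within the scatter) and stays within the scatter, so the size of the step depends on which group it replaces. Nothing at hand explains the larger step. Still open, going by these compounds, is how an amine or a carboxylic acid on the chain at this nitrogen would read in this assay and whether a ring without oxygen would match (oxolan-2-yl)methyl.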